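A few compounds are considered here, and "the series" means these few. Any claim that something is new, unique, unknown or untested is made for them only; others in the source may bear on it.

Measured so far in an assay on isolated protein for inhibition of DNA topoisomerase 1 (Homo sapiens), with a stated time of 30 min, tested at 100 uM; a higher number here means a stronger effect of the compound at the concentration tested, a lower number a weaker effect: compound 1 `Oc1ccc(-c2cc(-c3ccccc3)nc(-c3ccc(Cl)cc3)c2)cc1` gives 68%; compound 2 `Oc1ccc(-c2cc(-c3ccc(Cl)cc3)nc(-c3ccco3)c2)cc1` gives 15.8%; compound 3 `Oc1ccc(-c2cc(-c3cccc(Cl)c3)nc(-c3ccco3)c2)cc1` gives 25.5%.

Compound 4 `Oc1ccc(-c2cc(-c3ccccc3)nc(-c3cccc(Cl)c3)c2)cc1` has not yet been measured. Compared with compound 3 it carries phenyl in place of furan-2-yl on an aromatic carbon. The same kind of change is already seen between compound 2 and compound 1, namely (phenyl in place of furan-2-yl on an aromatic carbon), and there it gave a number 52.2 percentage points higher from compound 2 to compound 1 (beyond the scatter). The two cores are not identical: compound 3 differs from compound 2 by 3-chlorophenyl in place of 4-chlorophenyl on an aromatic carbon, so the new change sits beside a 3-chlorophenyl group where the earlier one sat beside a 4-chlorophenyl group, which makes it the same kind of change rather than the same change. That core difference itself gave a number 9.7 percentage points higher from compound 2 to compound 3 (within the scatter). For the measured compounds named here, the step from compound 3 to compound 4 is expected to be a number 44.5 percentage points higher from compound 3 to compound 4 (beyond the scatter), resting on the earlier step of a number 52.2 percentage points higher from compound 2 to compound 1 (beyond the scatter) and tempered somewhat, as only one such precedent exists. Compound 4 is therefore estimated at 70%, with a likely range from 45% to 90%.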

Compound 4, a percentage reported as inhibition, at one concentration (the size of the read-out at that concentration, not a potency): 0%
Compound 4: middle estimate off by 70 percentage points, on the high side; measured number outside the range, below it.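

The swap of furan-2-yl for phenyl does not carry over from one core to the other: in this assay it gives a number 25.5 percentage points lower from compound 3 to compound 4 (beyond the scatter), against the earlier step in the opposite direction: the same change on two cores in this assay, a number 52.2 percentage points higher (beyond the scatter) from compound 2 to compound 1 and a number 25.5 percentage points lower (beyond the scatter) from compound 3 to compound 4, 77.7 percentage points apart, beyond the scatter of two such steps

The change from 4-chlorophenyl to 3-chlorophenyl likewise differs between its two cores, giving a number 68 percentage points lower from compound 1 to compound 4 (beyond the scatter) on the core with phenyl: the same change on two cores in this assay, a number 9.7 percentage points higher (within the scatter) from compound 2 to compound 3 and a number 68 percentage points lower (beyond the scatter) from compound 1 to compound 4, 77.7 percentage points apart, beyond the scatter of two such steps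

So in these four compounds the outcome of each change depends on the group at the other site, though two pairs give no general rule and do not show why.

The compounds shown leave open how the furan-2-yl and phenyl swap behaves when an amine or a methoxy group stands in place of the chlorine.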